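This account rests on a few compounds, and the source may have more. Where it says the series, first, only, none or still open, it means among the compounds named here.

Compound 1, `Clc1cccc(-c2cc3n(n2)CCCC3)c1`: 77 nM
Compound 2, `COc1cccc(-c2cc3n(n2)CCCC3)c1`: 4500 nM

In a functional assay on HEK293 cells for negative allosteric modulation of metabotropic glutamate receptor 5 (Rattus norvegicus), read by FLIPR and calcium flux, with a stated time of 170 s (on this read-out higher numbers stand for weaker inhibition and lower numbers for stronger inhibition), compound 2 gives 4500 nM, the higher of the two numbers; its nearest neighbour is compound 1, which in this assay gives 77 nM. For the measured compounds named here, the only step between measured compounds, a 58-fold higher number from compound 1 to compound 2 (1.77 log units; beyond the scatter), is large and beyond the scatter.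

Compound 3, `Fc1cccc(-c2cc3n(n2)CCCC3)c1`, has not yet been measured in this assay. It differs from compound 2 by fluoro in place of methoxy on an aromatic carbon. The measured step bears on this change in reverse: it shows what a halogen to methoxy exchange on this aromatic carbon did, and the change to compound 3 undoes the methoxy in favour of another halogen. A large step downward in this assay is therefore expected, though fluoro is not chloro, so the full return is not assumed. Compound 3 is expected to give 300 nM, with a range from 80 nM to 1500 nM, an estimated step of a 15-fold lower number from compound 2 to compound 3 (1.18 log units; beyond the scatter).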

Compound 3, half-maximal inhibitory concentration: 1570 nM
For compound 3 the middle estimate is 5.2-fold (0.72 log units) below the measured one, and the stated range ends below it.
By their numbers in this assay, from the lowest: compound 1; then compound 3; then compound 2.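

In (this assay), the two halogens at this aromatic carbon are not interchangeable: the step from chloro to fluoro is large (a 20-fold higher number from compound 1 to compound 3 (1.31 log units; beyond the scatter)), so a halogen as such does not account for the low number of compound 1. Fluoro in place of methoxy brings only a modest change (a 2.9-fold lower number from compound 2 to compound 3 (0.46 log units; beyond the scatter)), which places the three groups in the order chloro, fluoro, methoxy from lowest number to highest, with every step among them beyond the scatter. Nothing available here explains this order.

The compounds shown leave open where bromo, nitrile or an amine on this same aromatic carbon would fall relative to chloro. They also leave open whether the same order would hold with these groups elsewhere on the six-membered aromatic ring.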